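The compounds below may be only part of what the source reports. "The series", "measured", "known", "first", "only" and "open" are said of these compounds alone.

Compound 1 (`COc1cc2ncnc(Nc3ccc(F)c(Cl)c3)c2cc1NC(=O)N/N=C/c1ccc(F)cc1`), compound 2 (`COc1cc2ncnc(Nc3ccc(F)c(Cl)c3)c2cc1NC(=O)N/N=C/c1ccc([N+](=O)[O-])cc1`) and compound 3 (`COc1cc2ncnc(Nc3ccc(F)c(Cl)c3)c2cc1NC(=O)N/N=C/c1cc(OC)c(OC)c(OC)c1`) share one core and differ only in the aromatic group on the carbon with a double bond to nitrogen. In a functional assay on PC-3 cells (Homo sapiens) for cytotoxicity, read by MTT assay, with a stated time of 72 h (on this read-out higher numbers stand for weaker inhibition and lower numbers for stronger inhibition), compound 1 gives 36500 nM, compound 2 gives 32400 nM and compound 3 gives 36500 nM. Compound 3 thus stands level with compound 1 and within the scatter of compound 2, so the three numbers form one flat group.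

The next structure, compound 4 (`COc1cc2ncnc(Nc3ccc(F)c(Cl)c3)c2cc1NC(=O)N/N=C/c1cc(Br)c(O)c(Br)c1`), changes the same place: 3,5-dibromo-4-hydroxyphenyl in place of 3,4,5-trimethoxyphenyl on a carbon with a double bond to nitrogen. Here 3,5-dibromo-4-hydroxyphenyl takes the place of 3,4,5-trimethoxyphenyl.

For the measured compounds named here, three measured steps bear on this change. Swapping the whole group gave no change at the digits printed from compound 1 to compound 3 (within the scatter) and a 1.1-fold higher number from compound 2 to compound 3 (0.05 log units; within the scatter), while changing only the substituent on that aromatic group gave a 1.1-fold lower number from compound 1 to compound 2 (0.05 log units; within the scatter). All three lie within the scatter. Going by the values given here, none of the measured compounds carries bromine or a hydroxyl on this group, so the evidence is indirect and the range must stay wide.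

On these small steps, no change beyond the scatter is expected in this assay, in either direction. The expected step is a 1.2-fold lower number from compound 3 to compound 4 (0.09 log units; within the scatter). Compound 4 is estimated at 30000 nM, with an expected range from 10000 nM to 65000 nM.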

Compound 4, half-maximal inhibitory concentration: 41500 nM
The estimate for compound 4 lay 1.4-fold (0.14 log units) below the measured number; low and high end bracket the measured number.
By their numbers in this assay, from the lowest: compounds 2, 1, 3 and 4 (each within the scatter of the next).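

In this assay, the swap to 3,5-dibromo-4-hydroxyphenyl gives a 1.1-fold higher number from compound 3 to compound 4 (0.06 log units; within the scatter), and the comparisons with the other two compounds give a 1.1-fold higher number from compound 1 to compound 4 (0.06 log units; within the scatter) and a 1.3-fold higher number from compound 2 to compound 4 (0.11 log units; within the scatter), so compound 4 joins the same flat group. Until now this place had held only fluoro, nitro and methoxy substituents; compound 4 adds bromine and a hydroxyl, yet all four aromatic groups on the carbon with a double bond to nitrogen remain within the scatter of one another in this cell assay. Nothing measured here explains why the numbers stay together.

The compounds shown leave open whether an amine or a carboxylic acid on this aromatic group, or a plain alkyl chain in place of the ring, would move the number beyond the scatter. They also leave open whether the same flatness would hold if the shared core itself were changed, since all four compounds carry it unaltered.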